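The source may hold more compounds than are shown below. What is called first, only, known or untested is meant among the compounds shown, and "the series" means these compounds.

Compounds measured in an assay on isolated protein for binding affinity to vitamin D3 receptor (Homo sapiens), read by fluorescence polarization, tested at 1 uM; a higher number here means more inhibition at the concentration tested (going by the name of the read-out), a lower number less inhibition:
compound 1, `CCN(CC)CCNC(=O)C1CC(C(CC)(CC)c2ccc(C#CC(C)(O)CC)c(C)c2)=CN1CC`: 59.2%
compound 2, `CCN(CC)CCNC(=O)C1CC(C(CC)(CC)c2ccc(C#CC(O)C3CCC3)c(C)c2)=CN1CC`: 49.3%
compound 3, `CCN(CC)CCNC(=O)C1CC=C(C(CC)(CC)c2ccc(C#CC(C)(C)O)c(C)c2)N1CC`: 60.2%

Among these three numbers compound 3 stands at the top, although its gap to compound 1 lies within the usual scatter of this assay; only its gap to compound 2 lies beyond it. Compound 4, `CCN(CC)CCNC(=O)C1CC=C(C(CC)(CC)c2ccc(C#CC(O)C3CCCC3)c(C)c2)N1CC`, is not yet measured. It differs from compound 3 in one place: cyclopentyl(hydroxy)methyl in place of 1-hydroxy-1-methylethyl on a triple-bonded carbon.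

One measured step resembles this change. From compound 1 to compound 2 a ring-bearing hydroxymethyl group replaced an acyclic hydroxyalkyl group on the same triple-bonded carbon, and this assay moved by a number 9.9 percentage points lower from compound 1 to compound 2 (within the scatter), a step that stays within the scatter. For the measured compounds named here, the change from compound 3 to compound 4 is of the same kind, with the five-membered ring entering in place of the 1-hydroxy-1-methylethyl group, and the core of compound 3 is the same as that of compound 4, so the earlier step is the only guide. On that basis compound 4 is expected to lie a little lower than compound 3, by a step of about a number 10.2 percentage points lower from compound 3 to compound 4 (beyond the scatter), which may or may not clear the scatter. The estimate for compound 4 in this assay is therefore 50%, within a range from 30% to 68%.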

Compound 4, a percentage reported as inhibition, at one concentration (the size of the read-out at that concentration, not a potency): 47.9%
Compound 4: the middle estimate sits 2.1 percentage points above what was measured, and the stated range covers the measured number.
By their numbers in this assay, from the lowest: compounds 4, 2, 1 and 3 (each within the scatter of the next, the first and the last beyond it).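

For the compounds shown here, on the core of compound 3, cyclopentyl(hydroxy)methyl in place of 1-hydroxy-1-methylethyl on a triple-bonded carbon gives a number 12.3 percentage points lower from compound 3 to compound 4 (beyond the scatter) in this assay, so a swap of this kind at this position can produce a change that clears the scatter, which the only earlier step at this carbon, a number 9.9 percentage points lower from compound 1 to compound 2 (within the scatter), did not do. Both steps run in the same direction, each with a ring-bearing group entering in place of an open-chain one, although they sit on different cores and involve different groups; the fall in compound 4 also comes with the hydrogen-bond donor and acceptor counts of the two groups unchanged.

The compounds shown leave open whether the ring itself or simply the larger group goes with the lower number, as the change to compound 4 alters both at once. They also leave open how a longer open chain carrying the hydroxyl, or an amine in place of that hydroxyl, would read at this position on the core of compound 3. Going by these compounds alone, nothing given here offers an explanation for the step from the one compound to the other.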